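The source may hold more compounds than are shown below. What is called first, only, known or untested is meant among the compounds shown, and "the series" means these compounds.

Compound 1 `Clc1cccc(-c2ccc(-c3ccc(-c4nc5ccccc5[nH]4)cc3)cc2)c1` and compound 2 `COc1ccc(-c2ccc(-c3ccc(-c4nc5ccccc5[nH]4)cc3)cc2)cc1OC` share a core in which the benzimidazole carries no hydroxy group. In a functional assay on ZR-75-1 cells (Homo sapiens) for inhibition, read by sulforhodamine B assay (a lower number here means a stronger inhibitor of growth, a higher number a weaker inhibitor of growth), compound 1 gives 41200 nM, and in this assay compound 2 gives 39700 nM. The two differ only in one place, (3,4-dimethoxyphenyl in place of 3-chlorophenyl on an aromatic carbon), and the step of a 1.0-fold lower number from compound 1 to compound 2 (0.02 log units; within the scatter) shows that this exchange leaves the read-out essentially unchanged.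

Compound 3 `Oc1cccc2[nH]c(-c3ccc(-c4ccc(-c5cccc(Cl)c5)cc4)cc3)nc12` carries a different core, which differs from that of compound 1 by hydroxy in place of hydrogen on an aromatic carbon. In this assay compound 3 gives 2410 nM, and the step of a 17-fold lower number from compound 1 to compound 3 (1.23 log units; beyond the scatter) is the largest movement among the three measured compounds, with compound 3 standing beyond the scatter from both compound 1 and compound 2.

Compound 4 `COc1ccc(-c2ccc(-c3ccc(-c4nc5c(O)cccc5[nH]4)cc3)cc2)cc1OC` has not yet been measured. It differs from compound 3 by 3,4-dimethoxyphenyl in place of 3-chlorophenyl on an aromatic carbon, which is the same change as that between compound 1 and compound 2, made at a place described in the same words. Because the step of a 1.0-fold lower number from compound 1 to compound 2 (0.02 log units; within the scatter) on the hydroxy-free core lies within the scatter, compound 4 is expected to sit close to compound 3, with an expected step of a 1.0-fold higher number from compound 3 to compound 4 (0.02 log units; within the scatter) in this assay. On this basis compound 4 is estimated at 2500 nM in this assay, with a likely range from 1000 nM to 6500 nM.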

Compound 4, concentration for 50% growth inhibition: 2110 nM
Compound 4: middle estimate off by 1.2-fold (0.07 log units), on the high side, and the stated range covers the measured number.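

In this assay, exchanging 3-chlorophenyl for 3,4-dimethoxyphenyl on the hydroxy-bearing core gives a 1.1-fold lower number from compound 3 to compound 4 (0.06 log units; within the scatter), and this exchange carries from one core to the other with no difference that can be told from the scatter: the same change on two cores in this assay, a 1.0-fold lower number (0.02 log units; within the scatter) from compound 1 to compound 2 and a 1.1-fold lower number (0.06 log units; within the scatter) from compound 3 to compound 4, 1.1-fold (0.04 log units) apart, within the scatter of two such steps. The hydroxy change, read on the pair with the 3,4-dimethoxyphenyl group, gives a 19-fold lower number from compound 2 to compound 4 (1.27 log units; beyond the scatter), and this large step also holds up when the end group is exchanged: the same change on two cores in this assay, a 17-fold lower number (1.23 log units; beyond the scatter) from compound 1 to compound 3 and a 19-fold lower number (1.27 log units; beyond the scatter) from compound 2 to compound 4, 1.1-fold (0.04 log units) apart, within the scatter of two such steps. Going by these compounds alone, this shows that the two changes combine independently in these four compounds in this one assay; it does not show that they would do so on any other core or in any other cell line, and the near-absence of a step for the end-group exchange says only that a very small step stayed very small.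

The compounds shown leave open whether the large step depends on the hydroxy group itself, or would also appear with a methoxy group, an amine or a carboxylic acid in its place. They also leave open whether the end ring is as indifferent to other groups, such as a nitrile or a basic amine chain, as it is to the two compared here.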